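A few compounds are considered here, and "the series" means these few. Any claim that something is new, unique, unknown or untested is made for them only; others in the source may bear on it.

The measured compounds:
Compound 1, `CC(C)(C)c1ccc2oc(N3CCCN(c4ncc(C(F)(F)F)cc4Cl)CC3)nc2c1`, in a physicochemical assay for solubility, at pH 7.4 (a higher number here means a more soluble compound, a lower number a less soluble compound), gives 0.1 ug/mL.
Compound 2, `CC(C)(C)c1cc(NC(=O)N2CCCN(C(=O)C3CCOCC3)CC2)no1`, in this assay gives > 96 ug/mL, which is a limit of the assay and not a number.
Compound 3, `CC(C)(C)c1ccc2oc(N3CCCN(C(=O)C4CCOCC4)CC3)nc2c1`, in this assay gives > 96 ug/mL, again a limit of the assay rather than a number.

So compound 3 stands at the top of what this assay can report, and it is not alone there: the limit of > 96 ug/mL in this assay, at which 2 of the 3 values shown sit. From the compounds shown here alone, how far above that limit compound 3 really lies is unknown. Among the compounds with values here, no pair of measured compounds differs in only one place, so no measured step can guide the next change.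

Compound 4, `CC(C)(C)c1ccc2oc(N3CCCN(C(=O)N4CCS(=O)(=O)CC4)CC3)nc2c1`, is not yet measured. Its difference from compound 3 is 1,1-dioxothiomorpholin-4-yl in place of oxan-4-yl on a carbonyl carbon. Within the data shown here, with no measured step to lean on, the expectation is simply that compound 4 stays where compound 3 is, with no move beyond the scatter, and that it too is likely to come back as a limit. The estimated step from compound 3 to compound 4 is a step that the limit leaves unreadable from compound 3 to compound 4. For compound 4 the expected value in this assay is 110 ug/mL, with a range from 40 ug/mL to 300 ug/mL.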

Compound 4, solubility: > 103 ug/mL
Compound 4: no number, only a limit; the forecaster's own chance of this, stated with the estimate: 65%; the middle value is on the limit's open side.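

Within the data shown here, compound 3 and compound 4 both come back from this assay as limits and not as numbers, so no step between them can be read. The compounds shown leave open how far past its limit each one really lies, and whether swapping oxan-4-yl for 1,1-dioxothiomorpholin-4-yl moves the reading at all.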